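Amino replacement on a nucleoside core: expecting compound 4

A few compounds are considered here, and "the series" means these few. Any claim that something is new, unique, unknown or untested is made for them only; others in the source may bear on it.

Compound 1, `COc1ncnc2c1c(-c1cccs1)cn2[C@@H]1O[C@H](CO)[C@@H](O)[C@H]1O`, in a functional assay on HeLa S3 cells (Homo sapiens) for antiproliferative activity, read by XTT assay, with a stated time of 72 h (a lower number here means a stronger inhibitor, a higher number a weaker inhibitor), gives 1760 nM.
Compound 2, `COc1nc(N)nc2c1c(-c1cccs1)cn2[C@@H]1O[C@H](CO)[C@@H](O)[C@H]1O`, in this assay gives only a limit of the assay, > 20000 nM.
Compound 3, `O=c1[nH]cnc2c1c(-c1ccco1)cn2[C@@H]1O[C@H](CO)[C@@H](O)[C@H]1O`, in this assay gives 5780 nM.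

Compounds 1 and 2 share a core and differ by one change, (amino in place of hydrogen on an aromatic carbon). That change gave an at least 11-fold higher number from compound 1 to compound 2 (1.05 log units; beyond the scatter). The large size of this step rests on (the limit of > 20000 nM in this assay, at which 1 of the 3 values shown sits), so its true extent is not known, only that it reaches that limit.

Compound 3 carries a different core; the difference between the two cores of compound 1 and compound 3 is not broken down here. Compound 4, `Nc1nc2c(c(-c3ccco3)cn2[C@@H]2O[C@H](CO)[C@@H](O)[C@H]2O)c(=O)[nH]1`, is not yet measured; it differs from compound 3 by amino in place of hydrogen on an aromatic carbon. Going by the values given here, this is the same kind of change as the one from compound 1 to compound 2, though in compound 1 the place is meta to a methoxy group (2 heavy atoms), whereas in compound 3 it is meta to a group of 1 heavy atom.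

Since compound 3 already starts at the higher end of the two numbers, compound 4 is expected to show a 7.8-fold higher number from compound 3 to compound 4 (0.89 log units; beyond the scatter) in this assay, a step estimated to be about as large as that seen from compound 1 to compound 2, which would most likely leave only a limit. The expected value for compound 4 is 45000 nM, with a range from 12000 nM to 150000 nM.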

Compound 4, half-maximal inhibitory concentration: > 20000 nM
Compound 4 ended at the assay's limit; the forecaster's own chance of this, stated with the estimate: 75%; the middle value lies beyond the limit too.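

Amino in place of hydrogen on an aromatic carbon weakens activity on the second core as well, with an at least 3.4-fold higher number from compound 3 to compound 4 (0.53 log units; beyond the scatter) in this assay, so the direction of the change carries across these two cores. Compound 4 gives > 20000 nM, which is a limit of the assay, so the full size of this step is not known. Whether the change costs the same on both cores cannot be told, because both steps end at a limit: the same change on two cores in this assay, an at least 11-fold higher number (1.05 log units; beyond the scatter) from compound 1 to compound 2 and an at least 3.4-fold higher number (0.53 log units; beyond the scatter) from compound 3 to compound 4; the limit leaves it open whether they differ

The compounds shown offer only these two pairs, so they leave open whether the same direction would hold on any further core. They also leave open whether a different group on that same carbon, such as methylamino, dimethylamino, methyl or chlorine, would weaken activity as amino does or would keep it closer to the values of compound 1 and compound 3.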